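Heteroaryl swaps on the ring nitrogen of the cyclic urea

The source may hold more compounds than are shown below. What is called first, only, known or untested is meant among the compounds shown, and "the series" means these compounds.

Three compounds have been measured in a functional assay on HEK293 cells for antagonist activity at P2X purinoceptor 7 (Homo sapiens); a lower number here means a stronger inhibitor, a higher number a weaker inhibitor:
compound 1 `Cc1ncccc1N1C[C@@H](C(=O)NCc2cccc(C(F)(F)F)c2Cl)N(C)C1=O` gives 5.01 nM
compound 2 `Cc1cccc(N2C[C@@H](C(=O)NCc3cccc(C(F)(F)F)c3Cl)N(C)C2=O)n1` gives 79.4 nM
compound 3 `Cc1cc(N2C[C@@H](C(=O)NCc3cccc(C(F)(F)F)c3Cl)N(C)C2=O)ccn1` gives 10 nM

Compound 3 stands second highest of the three numbers. Its nearest neighbour is compound 1, a gap within the scatter (a 2.0-fold higher number from compound 1 to compound 3 (0.30 log units; within the scatter)), and its furthest is compound 2 (a 7.9-fold lower number from compound 2 to compound 3 (0.90 log units; beyond the scatter)). The largest swing in the set comes from a 16-fold higher number from compound 1 to compound 2 (1.20 log units; beyond the scatter).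

Compound 4 `CN1C(=O)N(c2cn(C)cn2)C[C@H]1C(=O)NCc1cccc(C(F)(F)F)c1Cl` is not yet measured. It differs from compound 3 in one place: 1-methyl-1H-imidazol-4-yl in place of 2-methylpyridin-4-yl on an amide-type nitrogen in a ring. Going by the values given here, the steps that bear on this are the other exchanges of the group on the same ring nitrogen, which ranged from within the scatter (a 2.0-fold higher number from compound 1 to compound 3 (0.30 log units; within the scatter)) to large (a 16-fold higher number from compound 1 to compound 2 (1.20 log units; beyond the scatter)). Among the compounds with values here, no measured step exchanges a six-membered for a five-membered aromatic ring, so the direction in this assay is uncertain; a modest step toward a higher number is expected, a 3.0-fold higher number from compound 3 to compound 4 (0.48 log units; beyond the scatter). For compound 4 the estimate in this assay is 30 nM, with a range from 6 nM to 150 nM.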

Compound 4, half-maximal inhibitory concentration: 2.51 nM
Compound 4: middle estimate off by 12-fold (1.08 log units), on the high side, and the stated range ends above it.
By their numbers in this assay, from the lowest: compounds 4, 1 and 3 (each within the scatter of the next, the first and the last beyond it); then compound 2.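

In this assay, a five-membered aromatic ring serves on the ring nitrogen as well as a six-membered one: a 2.0-fold lower number from compound 1 to compound 4 (0.30 log units; within the scatter) separates 1-methyl-1H-imidazol-4-yl from 2-methylpyridin-3-yl by no more than the usual scatter. Against the other two pyridines the exchange does register, with a 4.0-fold lower number from compound 3 to compound 4 (0.60 log units; beyond the scatter) and a 32-fold lower number from compound 2 to compound 4 (1.50 log units; beyond the scatter), the latter being the widest step in the set, so the group on this nitrogen still separates the compounds strongly. No evidence is available that bears on the reason for these differences.

The compounds shown leave open what the methyl group on the imidazole ring contributes, and how a thiazole, a pyrazole or a plain phenyl ring would read on the same nitrogen. As far as these compounds go, whether these steps hold with a different benzyl amide on the shared core also remains open.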